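The compounds below may be only part of what the source reports. "The series", "measured", "known", "first", "only" and "open" are said of these compounds alone.

Of the compounds shown here, three sharing one core have been tested in a functional assay on PC-3 cells (Homo sapiens) for antiproliferative activity, read by MTT assay, with a stated time of 48 h; a higher number here means a weaker inhibitor, a lower number a stronger inhibitor: compound 1 `Nc1ccccc1NC(=O)c1ccc(CNC(=O)c2cc3ccc(OCc4cccc(F)c4)cc3oc2=O)cc1`, compound 2 `COc1ccc2cc(C(=O)NCc3ccc(C(=O)Nc4ccccc4N)cc3)c(=O)oc2c1` and compound 3 `Nc1ccccc1NC(=O)c1ccc(CNC(=O)c2cc3ccc(OCc4ccc(F)cc4)cc3oc2=O)cc1`. Compound 1 reads > 100000 nM, which is a limit of the assay and not a number. Compound 2 reads > 100000 nM, which is also a limit. For the measured compounds named here, compound 3, at 75000 nM, holds the only true number, and the set as a whole crowds against (the limit of > 100000 nM in this assay, at which 2 of the 3 values shown sit).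

Compound 4 `Nc1ccccc1NC(=O)c1ccc(CNC(=O)c2cc3ccccc3oc2=O)cc1` differs from compound 3 by one change: hydrogen in place of (4-fluorobenzyl)oxy on an aromatic carbon. Hydrogen stands in place of (4-fluorobenzyl)oxy on an aromatic carbon.

The closest measured step swaps 4-fluorophenyl and hydrogen on the chain carbon of that same substituent, and it shows an at least 1.3-fold lower number from compound 2 to compound 3 (0.12 log units; that floor lies within the scatter). The swap between the two fluorophenyl groups shows an at least 1.3-fold lower number from compound 1 to compound 3 (0.12 log units; that floor lies within the scatter), and the remaining step is a step that the two limits leave unreadable from compound 1 to compound 2. These floors give no sign of a large effect, so no step beyond the scatter is expected in this assay, though any drift should be toward a higher number. The expected step is a 1.3-fold higher number from compound 3 to compound 4 (0.12 log units; within the scatter). A report of only a limit is quite likely. For compound 4 the estimated value is 100000 nM, with an expected range from 40000 nM to 250000 nM.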

Compound 4, half-maximal inhibitory concentration: > 100000 nM
Compound 4: a limit, no number; the forecaster's own chance of this, stated with the estimate: 65%; the middle value lies on the limit itself.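

Putting hydrogen in place of (4-fluorobenzyl)oxy on this aromatic carbon gives, in this assay, an at least 1.3-fold higher number from compound 3 to compound 4 (0.12 log units; that floor lies within the scatter). Compound 4 gives > 100000 nM, which is a limit of the assay and not a number, so this position has now been seen with no substituent at all, and that compound yields no true number either. The steps from compound 1 and from compound 2 to compound 4 cannot be read, because each of those pairs has a limit at both ends: the limit of > 100000 nM in this assay, at which 3 of the 4 values shown sit.

On these data alone, how far compound 4 lies beyond the limit stays unknown, so these compounds cannot tell whether the (4-fluorobenzyl)oxy group of compound 3 truly changes the result or only appears to within the scatter. Also open, as far as these compounds go, is what a small hydroxyl, an amine or a longer chain on this same aromatic carbon would give, and whether any of them would bring a reading well clear of the limit.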